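This account rests on a few compounds, and the source may have more. Where it says the series, first, only, none or still open, it means among the compounds named here.

Measured in an ADME assay on microsomes from liver (Homo sapiens) for metabolic stability, read by LC-MS, using NADPH, with stated times of 10 min and 30 min; on this read-out lower numbers stand for slow clearance and higher numbers for fast clearance:
- Compound 1 `CC1(C)c2cc(Cl)ccc2C(=O)N1c1cccnc1`: < 3.5 mL/min/kg, a limit
- Compound 2 `CCS(=O)(=O)N[C@@H]1CCCc2c1cncc2N1Cc2cc(Cl)ccc2C1=O`: < 3.5 mL/min/kg, a limit
- Compound 3 `CCC(=O)N[C@@H]1CCCc2c1cncc2N1Cc2cc(Cl)ccc2C1=O`: < 3.5 mL/min/kg, a limit

Compound 3 has no exact number, only this limit of the assay. All three compounds share (the limit of < 3.5 mL/min/kg in this assay, at which 3 of the 3 values shown sit).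

Compound 4 `CS(=O)(=O)N[C@@H]1CCCc2c1cncc2N1Cc2cc(Cl)ccc2C1=O` has methylsulfonyl in place of propanoyl on an amine nitrogen. For the measured compounds named here, the one measured step that bears on this change is a step that the two limits leave unreadable from compound 2 to compound 3. It swaps propanoyl for ethylsulfonyl on the same amine nitrogen, a similar exchange run the other way. Both of its ends are limits, so it offers no size and no direction. Nothing measured therefore points to a real shift in this assay, and clearance is expected to stay low. The expected change is a step that the limit leaves unreadable from compound 3 to compound 4, which is no more than the usual scatter. For compound 4 the estimated clearance is 3 mL/min/kg, with an expected range of 2 mL/min/kg to 5 mL/min/kg, and the assay will quite likely report only a limit again.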

Compound 4, clearance: < 3.5 mL/min/kg
Compound 4 ended at the assay's limit; the forecaster's own chance of this, stated with the estimate: 80%; the middle value lies beyond the limit too.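

No new step can be read among compound 2, compound 3 and compound 4 in this assay, because each end of every step is a limit and not a number: the limit of < 3.5 mL/min/kg in this assay, at which 4 of the 4 values shown sit.

Whether the true clearances of these compounds differ at all, and by how much, stays open.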